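Pyrimidinyl in place of chlorophenyl on a piperazine sulfonamide

The source may report more compounds than this note shows. Statements on the series, on what has been measured and on what is new or still open speak of the compounds shown alone.

Measured so far:
compound 1, `O=C1c2ccccc2S(=O)(=O)N1CCCCCN1CCN(c2ccc(Cl)cc2)CC1`: 191 nM in an assay on HEK293 cells for displacement of a labelled ligand from 5-hydroxytryptamine receptor 7 (Homo sapiens); a lower number here means a stronger inhibitor, a higher number a weaker inhibitor
compound 2, `O=C1c2ccccc2S(=O)(=O)N1CCCCCN1CCN(c2ccccc2)CC1`: 148 nM in this assay

Compound 1 and compound 2 sit within the scatter of each other, so neither stands apart. Compound 3, `O=C1c2ccccc2S(=O)(=O)N1CCCCCN1CCN(c2ncccn2)CC1`, carries pyrimidin-2-yl in place of 4-chlorophenyl on an amine nitrogen in a ring. No measured step makes this change; the only step shown, a 1.3-fold lower number from compound 1 to compound 2 (0.11 log units; within the scatter), puts hydrogen in place of chloro and stays within the scatter, so the phenyl ring bears that loss. For pyrimidin-2-yl there is no guide, so at most a modest weakening is expected. For compound 3 the estimate is 300 nM (80 nM to 1200 nM), an expected step of a 1.6-fold higher number from compound 1 to compound 3 (0.20 log units; within the scatter).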

Compound 3, inhibition constant: 2670 nM
Compound 3: middle estimate off by 8.9-fold (0.95 log units), on the low side; the measured number lies above the stated range.
By their numbers in this assay, from the lowest: compounds 2 and 1 (each within the scatter of the next); then compound 3.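

Changing the group on the ring amine nitrogen matters far more than the earlier chloro-to-hydrogen change did: in this assay, pyrimidin-2-yl weakens binding clearly, both against 4-chlorophenyl (a 14-fold higher number from compound 1 to compound 3 (1.15 log units; beyond the scatter)) and against phenyl (an 18-fold higher number from compound 2 to compound 3 (1.26 log units; beyond the scatter)). At this position, then, the phenyl ring with or without chloro gives similar numbers, while pyrimidin-2-yl does not keep them. Nothing available explains this loss.

Still open, from the compounds shown here alone, is whether a pyridin-2-yl or 2-methoxyphenyl group would keep the strength of compound 2, and whether the pyrimidin-2-yl loss would persist with a shorter chain.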